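The source may report more compounds than this note shows. Statements on the series, on what has been measured and on what is new or still open speak of the compounds shown alone.

Compound 1 `O=C1COc2ccc(-c3cccc(NS(=O)(=O)c4ccc(F)cc4)c3)cc2N1C1CC1` carries a cyclopropyl on an amide-type nitrogen in a ring. In a functional assay on MCF7 cells (Homo sapiens) for antiproliferative activity, read by MTT assay, with a stated time of 72 h (on this read-out higher numbers stand for weaker inhibition and lower numbers for stronger inhibition), compound 1 gives only a limit, > 40000 nM. Two related compounds were also measured. Compound 2 `O=C1COc2ccc(-c3cnc4ccccc4c3)cc2N1c1ccc(Cl)cc1` likewise gives only a limit, > 40000 nM. Compound 3 `COc1cccc(N2C(=O)COc3ccc(-c4cnc5ccccc5c4)cc32)c1` again gives only a limit, > 40000 nM. The step that the two limits leave unreadable from compound 2 to compound 3 therefore cannot be read because both ends sit at the limit of > 40000 nM in this assay, at which 3 of the 3 values shown sit. Compound 4 `O=C1COc2ccc(-c3cccc(NS(=O)(=O)c4ccc(F)cc4)c3)cc2N1` differs from compound 1 by hydrogen in place of cyclopropyl on an amide-type nitrogen in a ring. Within the data shown here, no measured step bears on this change, and every value shown is a limit, so no step beyond the scatter can be foreseen in this assay in either direction. Compound 4 is expected to give 60000 nM, within 15000 nM to 250000 nM, most likely again only a limit. The expected step is a step that the limit leaves unreadable from compound 1 to compound 4.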

Compound 4, half-maximal inhibitory concentration: 18300 nM
Beside the measured number, compound 4's estimate is 3.3-fold (0.52 log units) above it, and the stated range covers the measured number.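

Putting hydrogen in place of cyclopropyl on the amide-type nitrogen gives an at least 2.1-fold lower number from compound 1 to compound 4 (0.33 log units; beyond the scatter) in this assay, the only readable step among these compounds. It shows that this nitrogen needs no carbon group for a measurable number to appear, and that hydrogen there outperforms cyclopropyl. The true size of the step may be larger, because compound 1 reaches only a limit: the limit of > 40000 nM in this assay, at which 3 of the 4 values shown sit.

Still open, as far as these compounds go, is whether a methyl, or a longer chain ending in an amine, on this nitrogen would stay close to compound 4 or fall back to the limit.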